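Switching isopropyl for methoxy on a weak anilinopyrimidine

The source may report more compounds than this note shows. Statements on the series, on what has been measured and on what is new or still open speak of the compounds shown alone.

Compound 1, `Cc1cnc(Nc2ccc(C(C)C)cc2)nc1Nc1nc2ccccc2s1`, is tested in a functional assay on PC-3 cells (Homo sapiens) for antiproliferative activity, read by MTT assay, with a stated time of 48 h; on this read-out lower numbers stand for stronger inhibition and higher numbers for weaker inhibition. There compound 1 reaches only the limit of > 50000 nM, which is a boundary of the assay and not a number, as the limit of > 50000 nM in this assay, at which 1 of the 2 values shown sits, records. Compound 2, `CS(=O)(=O)c1ccc(Nc2nccc(Nc3nc4ccccc4s3)n2)cc1`, carries a methylsulfonyl group on its aniline and no methyl on the shared core; in this assay compound 2 gives 1710 nM. Among the measured compounds shown here, no step between measured compounds is available, so the change to compound 3, `COc1ccc(Nc2ncc(C)c(Nc3nc4ccccc4s3)n2)cc1`, is judged from its structure alone: methoxy in place of isopropyl on an aromatic carbon. The step from compound 1 to compound 3 is expected to be an at least 2.0-fold lower number from compound 1 to compound 3 (0.30 log units; that floor lies within the scatter), most likely small or none beyond the scatter. Compound 3 is accordingly estimated at 25000 nM, within a range from 4000 nM to 50000 nM.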

Compound 3, half-maximal inhibitory concentration: > 50000 nM
Compound 3: a limit, no number; the forecaster's own chance of this, stated with the estimate: 45%; at least 2.0-fold (0.30 log units) between middle value and limit.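

Compound 3 ends at a limit of the assay, as compound 1 does, so no step can be read from compound 1 to compound 3: the limit of > 50000 nM in this assay, at which 2 of the 3 values shown sit. The compounds shown leave open whether methoxy in place of isopropyl on an aromatic carbon changes the antiproliferative activity at all.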